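The source may hold more compounds than are shown below. What is called first, only, known or untested is meant among the compounds shown, and "the series" means these compounds.

Compounds measured so far:

Compound 1, `COc1cc(C)cc(-c2c(-c3ccnc(-c4ccc(N(C)C)cc4)c3)cnn2CC#N)c1`. In a functional assay on MOLT-4 cells (Homo sapiens) for inhibition, read by sulforhodamine B assay, with a stated time of 48 h (on this read-out higher numbers stand for lower toxicity in this test and lower numbers for higher toxicity in this test), compound 1 reaches only the limit of the test, > 100000 nM.

Compound 2, `Cc1cc(O)cc(-c2nn(CC#N)cc2-c2ccnc(-c3ccc(Oc4ccccc4)cc3)c2)c1`. In this assay compound 2 likewise reaches only the limit, > 100000 nM.

Neither value is a number; both are limits of the test, and compound 1 therefore stands at the limit of > 100000 nM in this assay, at which 2 of the 2 values shown sit. Among the measured compounds shown here, the two measured compounds do not differ in one place only, so no single step between them can be read, and all that their two values show is that both sit at the same limit.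

The unmeasured compound is compound 3, `COc1cc(C)cc(-c2c(-c3ccnc(-c4ccc(C(C)=O)cc4)c3)cnn2CC#N)c1`. It follows from compound 1 by a single change, (acetyl in place of dimethylamino on an aromatic carbon). For the measured compounds named here, no measured step of this kind is available to guide the reading. Given that compound 1 gives > 100000 nM in this assay, the change from dimethylamino to acetyl is expected to move the read-out by no step beyond the scatter, a step that the limit leaves unreadable from compound 1 to compound 3. The estimate for compound 3 in this assay is 150000 nM, with a range from 60000 nM to 400000 nM, most likely reported again as a limit rather than a number.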

Compound 3, concentration lethal to 50% of the cells: > 100000 nM
Compound 3 ended at the assay's limit (the forecaster's own chance of this, stated with the estimate: 80%); the middle value is on the limit's open side.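

In this assay compound 3 gives > 100000 nM, a limit of the test and not a number. Among the compounds shown here, compound 1 also stands at a limit, so no step between compound 1 and compound 3 can be read. The compounds shown leave open what true value any of them has, and what in their structures would change it, since all sit at one limit: the limit of > 100000 nM in this assay, at which 3 of the 3 values shown sit.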